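Shrinking trifluoromethyl to fluoro in a histone deacetylase 8 series

The source may report more compounds than this note shows. Statements on the series, on what has been measured and on what is new or still open speak of the compounds shown alone.

Compound 1 `CC(C)[C@@H](C(=O)Nc1ccc(C(=O)Nc2ccccc2N)cc1)c1ccccc1`: 38%
Compound 2 `CC(C)[C@@H](C(=O)Nc1ccc(C(=O)Nc2ccc(C(F)(F)F)cc2N)cc1)c1ccccc1`: 0%

Of the compounds shown here, two have been measured in an assay on isolated protein for inhibition of histone deacetylase 8 (Homo sapiens), read by fluorescence, tested at 1 uM; a lower number here means less inhibition, a higher number more inhibition at the concentration tested (going by the name of the read-out). Compound 1 gives 38%, and compound 2 gives 0%. Going by the values given here, compound 2 thus stands lowest of the two numbers; its only neighbour is compound 1, and the step of a number 38 percentage points lower from compound 1 to compound 2 (beyond the scatter) is the one measured change, a large drop on putting trifluoromethyl in place of hydrogen on an aromatic carbon.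

Compound 3 `CC(C)[C@@H](C(=O)Nc1ccc(C(=O)Nc2ccc(F)cc2N)cc1)c1ccccc1` is not yet measured. It differs from compound 2 in one place: fluoro in place of trifluoromethyl on an aromatic carbon. Fluoro brings fewer heavy atoms than trifluoromethyl, and compound 1, carrying hydrogen, is the only other point of reference, so a partial return toward the value of compound 1 seems plausible, though a single step is thin ground. The expected step is a number 20 percentage points higher from compound 2 to compound 3 (beyond the scatter), upward. For compound 3 the estimate in this assay is 20%, within the range 2% to 40%.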

Compound 3, a percentage reported as inhibition, at one concentration (the size of the read-out at that concentration, not a potency): 6%
The estimate for compound 3 lay 14 percentage points above the measured number; measured number inside the range.
By their numbers in this assay, from the lowest: compounds 2 and 3 (each within the scatter of the next); then compound 1.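

In this assay, replacing trifluoromethyl with fluoro gives a number 6 percentage points higher from compound 2 to compound 3 (within the scatter), so shrinking the group from 4 heavy atoms to 1 brings no recovery that can be told apart from scatter. The comparison with hydrogen is the new finding: a number 32 percentage points lower from compound 1 to compound 3 (beyond the scatter) shows that a single fluoro, placed meta to an amino group and para to a large group, is enough for a large loss, so the drop does not require the full trifluoromethyl group. Nothing available here explains this loss.

Still open, going by these compounds, is whether a methyl group, a chlorine or a methoxy group at this place would behave the same way. Readings at a single concentration also leave open how these compounds compare in potency.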